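Thiophene in Place of Phenyl on Two Related Cores

The compounds below may be only part of what the source reports. "The series", "measured", "known", "first", "only" and "open" are said of these compounds alone.

Compound 1 `Cc1nc(N)c2c(-c3ccccc3)cn([C@@H]3O[C@H](CO)[C@@H](O)[C@H]3O)c2n1`: > 20000 nM
Compound 2 `Cc1nc(N)c2c(-c3cccs3)cn([C@@H]3O[C@H](CO)[C@@H](O)[C@H]3O)c2n1`: > 20000 nM
Compound 3 `CNc1ncnc2c1c(-c1ccccc1)cn2[C@@H]1O[C@H](CO)[C@@H](O)[C@H]1O`: > 20000 nM

In a functional assay on K562 cells (Homo sapiens), read by MTT assay, with a stated time of 72 h (a higher number here means a weaker inhibitor, a lower number a stronger inhibitor), compound 1 reaches only a limit, > 20000 nM. Compound 2 likewise reaches only a limit, > 20000 nM. The core of compound 1 differs from the core of compound 3 in a way that is not broken down here, and compound 3 also stops at a limit, > 20000 nM. The change thiophen-2-yl in place of phenyl on an aromatic carbon thus yields a step that the two limits leave unreadable from compound 1 to compound 2. Compound 4 `CNc1ncnc2c1c(-c1cccs1)cn2[C@@H]1O[C@H](CO)[C@@H](O)[C@H]1O` carries the same change on the core of compound 3, (thiophen-2-yl in place of phenyl on an aromatic carbon), and is still to be measured in this assay. The expected step that the limit leaves unreadable from compound 3 to compound 4 is set beside a step that the two limits leave unreadable from compound 1 to compound 2 and rests on (the limit of > 20000 nM in this assay, at which 3 of the 3 values shown sit). Compound 4 is expected to give 30000 nM, with an estimated range from 12000 nM to 100000 nM, and most probably again only a limit.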

Compound 4, half-maximal inhibitory concentration: > 20000 nM
Compound 4: no number, only a limit; the forecaster's own chance of this, stated with the estimate: 85%; the middle value does not contradict the limit.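

Among these compounds, compound 3 and compound 4 both stop only at a limit in this assay, so no step between them can be read. The compounds shown leave open whether thiophen-2-yl in place of phenyl changes the read-out on either core.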